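Capping the phenol versus replacing it in the amide series

This account rests on a few compounds, and the source may have more. Where it says the series, first, only, none or still open, it means among the compounds named here.

Among the measured compounds shown here, compound 2 `COc1cc(/C=C/C(=O)NCc2ccc(OCc3nc(C)c(C)nc3C)c(OC)c2)ccc1O` gives 13400 nM in a functional assay on SH-SY5Y cells (Homo sapiens) for cytotoxicity, read by MTT assay, with stated times of 24 h and 4 h (a higher number here means that more compound is needed for the effect, a lower number that less compound is needed), the highest of the three numbers measured so far. Its nearest neighbour is compound 3 `COc1cc(/C=C/C(=O)NCc2ccc(OCc3nc(C)c(C)nc3C)c(OC)c2)ccc1OCc1nc(C)c(C)nc1C`, which gives 11100 nM in this assay; the change a 1.2-fold lower number from compound 2 to compound 3 (0.08 log units; within the scatter) stays within the scatter. Furthest off is compound 1 `COc1cc(CNC(=O)/C=C/c2ccccc2OCc2nc(C)c(C)nc2C)ccc1OCc1nc(C)c(C)nc1C`, which gives 6280 nM in this assay, a number beyond the scatter lower than that of compound 2.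

Compound 4 `COc1cc(/C=C/C(=O)NCc2ccc(OCc3nc(C)c(C)nc3C)c(OC)c2)cc(OC)c1` is not yet measured. It differs from compound 2 by 3,5-dimethoxyphenyl in place of 4-hydroxy-3-methoxyphenyl on a double-bonded chain carbon bound to a double-bonded chain carbon. For the measured compounds named here, the only measured step that bears on this is the one from compound 2 to compound 3, where the phenol oxygen was capped with the (3,5,6-trimethylpyrazin-2-yl)methyl group, so that the hydrogen-bond donor was lost, and the number moved by a 1.2-fold lower number from compound 2 to compound 3 (0.08 log units; within the scatter), within the scatter. Going by the values given here, no measured pair covers a shift of the methoxy groups on that ring. On this basis compound 4 is expected to show a step of a 1.1-fold lower number from compound 2 to compound 4 (0.05 log units; within the scatter) from compound 2, not beyond the scatter. The estimate for compound 4 in this assay is 12000 nM, with a range from 5000 nM to 30000 nM.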

Compound 4, half-maximal effective concentration: 8660 nM
Compound 4: the middle estimate sits 1.4-fold (0.14 log units) above what was measured, and the stated range covers the measured number.
By their numbers in this assay, from the lowest: compounds 1, 4, 3 and 2 (each within the scatter of the next, the first and the last beyond it).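

Replacing 4-hydroxy-3-methoxyphenyl with 3,5-dimethoxyphenyl on a double-bonded chain carbon bound to a double-bonded chain carbon gives, in this assay, a 1.5-fold lower number from compound 2 to compound 4 (0.19 log units; within the scatter). This is the first change shown that alters the aromatic group itself, with 1 hydrogen-bond donor leaving, 0 entering and 2 hydrogen-bond acceptors on both sides, and it adds to a 1.2-fold lower number from compound 2 to compound 3 (0.08 log units; within the scatter), where the phenol oxygen was capped with (3,5,6-trimethylpyrazin-2-yl)methyl: two structurally different ways of removing the phenol hydrogen both leave the number within the scatter of compound 2, so in these two pairs neither the capped phenol nor the rearranged methoxy pattern separates from the parent in this read-out. No measurement on hand accounts for the size of this step or for the effect of either change on the cells.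

The step from compound 2 to compound 4 removes the hydroxyl and shifts the methoxy group in a single change, so the contribution of each remains unresolved. Also open, from the compounds shown here alone, is whether an unsubstituted phenyl, or a phenyl carrying an amine or a carboxylic acid, at this place would move the number beyond the scatter of compound 2.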